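A Dichlorophenyl Replaces an Ethylphenyl on the Aromatic Nitrogen

The source may report more compounds than this note shows. Statements on the series, on what has been measured and on what is new or still open speak of the compounds shown alone.

Compound 3 `CCc1ccccc1-n1nncc1CN1C(=O)C2(C(C#N)=C(N)Oc3c(N)cc4nc5ccccc5nc4c32)c2ccccc21` gives 10300 nM in a functional assay on HCT-116 cells (Homo sapiens) for antiproliferative activity, read by MTT assay, with a stated time of 48 h; on this read-out higher numbers stand for weaker inhibition and lower numbers for stronger inhibition. Compound 2 `N#CC1=C(N)Oc2c(c3nc4ccccc4nc3c3ccccc23)C12C(=O)N(Cc1cnnn1-c1cccc(S(N)(=O)=O)c1)c1ccccc12` gives 11300 nM in this assay, and since the two numbers sit within the scatter of each other, compound 3 merely holds the lowest of the two numbers shown, with compound 2 right beside it. Compound 1 `N#CC1=C(N)Oc2c(c3nc4ccccc4nc3c3ccccc23)C12C(=O)N(Cc1cnnn1-c1ccc(Cl)cc1)c1ccccc12` reaches only a limit of this assay, > 50000 nM, which is the limit of > 50000 nM in this assay, at which 1 of the 3 values shown sits. Within the data shown here, the single measured step, an at least 4.4-fold lower number from compound 1 to compound 2 (0.64 log units; beyond the scatter), swaps one aryl group for another on the same aromatic nitrogen that is changed here. Compound 4 `N#CC1=C(N)Oc2c(N)cc3nc4ccccc4nc3c2C12C(=O)N(Cc1cnnn1-c1ccc(Cl)cc1Cl)c1ccccc12` differs from compound 3 by 2,4-dichlorophenyl in place of 2-ethylphenyl on an aromatic nitrogen. The measured step shows that an aryl exchange at this nitrogen can move the number beyond the scatter, and compound 1, which also carries a chlorine-bearing aryl there, reached only a limit. Compound 4 is therefore expected to give a somewhat higher number, 18000 nM, between 6000 nM and 50000 nM, an estimated step of a 1.7-fold higher number from compound 3 to compound 4 (0.24 log units; within the scatter).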

Compound 4, half-maximal inhibitory concentration: > 50000 nM
Compound 4: no number, only a limit (the forecaster's own chance of this, stated with the estimate: 30%); at least 2.7-fold (0.44 log units) between middle value and limit.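

On the core of compound 3, the exchange gives an at least 4.8-fold higher number from compound 3 to compound 4 (0.68 log units; beyond the scatter), so the aryl group on this nitrogen matters on a second core as well, not only on the core of compounds 1 and 2. The 2-ethylphenyl and 2,4-dichlorophenyl groups have the same count of heavy atoms and neither has hydrogen-bond donors or acceptors, so these counts do not separate them. Compound 4 sits at a limit of this assay, as does compound 1 on its different core: the limit of > 50000 nM in this assay, at which 2 of the 4 values shown sit.

The compounds shown leave open which of the two chlorines in compound 4 matters, and how far the number could be lowered on this core. An aryl group carrying an amine or a carboxylic acid at this nitrogen also remains an open case.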